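The source may hold more compounds than are shown below. What is called first, only, known or untested is meant among the compounds shown, and "the series" means these compounds.

Measured in a physicochemical assay for lipophilicity, in phosphate buffer, measured as octanol-water partition, with a stated time of 24 h; on this read-out higher numbers stand for higher lipophilicity and lower numbers for lower lipophilicity:
Compound 1, `S=C(N/N=C/c1ccc(Oc2ccc(Br)cc2)cc1)Nc1ccccc1`: 5.62
Compound 2, `S=C(N/N=C/c1ccc(Oc2ccc(Cl)cc2)cc1)Nc1ccccc1`: 5.52
Compound 3, `Cc1cc(Oc2ccc(/C=N/NC(=S)Nc3ccc(Br)cc3)cc2)ccc1Cl`: 7.89

Of these three numbers, compound 3 stands highest. Its nearest neighbour is compound 1, and that gap already lies beyond the scatter of the measurement; the gap to compound 2 is wider still. Going by the values given here, only one measured step exists in this set, between compound 1 and compound 2: a number 0.10 log units lower from compound 1 to compound 2 (within the scatter), a swap of one halogen for another on an aromatic carbon that leaves the number essentially where it was.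

Compound 4, `Cc1cc(Oc2ccc(/C=N/NC(=S)Nc3ccccc3)cc2)ccc1Cl`, is compound 3 with a single change: hydrogen in place of bromo on an aromatic carbon. The measured step bears on this only loosely, since it exchanges one halogen for another rather than removing a halogen outright; it shows that the two halogens read alike in this assay but does not fix what a hydrogen in that place would do. Among the compounds with values here, no measured pair isolates that change. The expected step is therefore a moderate fall, a number 0.89 log units lower from compound 3 to compound 4 (beyond the scatter), clearly smaller than the gap that separates compound 3 from compound 1. Compound 4 is accordingly estimated at 7, with a range from 6.5 to 7.5.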

Compound 4, partition coefficient: 6.03
Compound 4: the middle estimate sits 0.97 log units above what was measured; measured number below the stated range.
By their numbers in this assay, from the lowest: compounds 2 and 1 (each within the scatter of the next); then compound 4; then compound 3.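

In this assay, taking the bromo away to leave a plain phenyl gives a number 1.86 log units lower from compound 3 to compound 4 (beyond the scatter), so this position can carry a large step, which the earlier swap of one halogen for another could not show. Compound 4 also links this position to the rest of the set: methyl in place of hydrogen gives a number 0.51 log units higher from compound 2 to compound 4 (beyond the scatter), and 4-chloro-3-methylphenyl in place of 4-bromophenyl gives a number 0.41 log units higher from compound 1 to compound 4 (beyond the scatter), both modest beside the large step for losing the bromo. Nothing available explains the size of any of these steps.

The compounds shown leave open what a methoxy group or an amine would do in the place the bromo held, and so whether the number follows any simple order across groups at that position. Going by these compounds alone, they also leave open whether losing the bromo gives a step of the same size in a compound without the methyl, since the one step here comes from a single pair.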